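Closing a ring onto the pyridine: from compound 3 to compound 4

The source may hold more compounds than are shown below. What is called first, only, known or untested is meant among the compounds shown, and "the series" means these compounds.

Compound 1 `CCC(=O)NCc1cncc(N2C(=O)c3ccc(Cl)cc3C2(C)C)c1`: 282 nM
Compound 2 `CC(=O)N1CC[C@@H](Oc2cncc(N3C(=O)c4ccc(Cl)cc4C3(C)C)c2)C1`: 11 nM
Compound 3 `CC1(C)c2cc(Cl)ccc2C(=O)N1c1cccnc1`: 108 nM

In an assay on cells for inhibition of cytochrome P450 11B2, mitochondrial (Homo sapiens), read by HTRF (a lower number here means a stronger inhibitor, a higher number a weaker inhibitor), compound 3 gives 108 nM, which stands second highest of the three numbers; compound 1 gives 282 nM and compound 2 gives 11 nM. Compound 4 `CC(=O)N1CCC(c2cncc(N3C(=O)c4ccc(Cl)cc4C3(C)C)c2)CC1` has not yet been measured. It differs from compound 3 by 1-acetylpiperidin-4-yl in place of hydrogen on an aromatic carbon, the new group being one six-membered non-aromatic ring with 1 hetero atom, placed two atoms from the ring nitrogen and meta to a large group.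

For the measured compounds named here, two measured steps bear on this. Taking the ring-bearing acetylated group away gives a 9.8-fold higher number from compound 2 to compound 3 (0.99 log units; beyond the scatter), so that group is a clear gain, whereas taking the open-chain amide away gives a 2.6-fold lower number from compound 1 to compound 3 (0.42 log units; beyond the scatter), so that amide is a loss. Compound 4 carries an acetylated saturated ring like compound 2 but attached through carbon rather than oxygen, so a gain smaller than that of compound 2 is expected, a 3.6-fold lower number from compound 3 to compound 4 (0.56 log units; beyond the scatter).

The value for compound 4 in this assay is therefore estimated at 30 nM, with a range from 8 nM to 110 nM.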

Compound 4, half-maximal inhibitory concentration: 5 nM
Beside the measured number, compound 4's estimate is 6.0-fold (0.78 log units) above it, outside the stated range (below it).
By their numbers in this assay, from the lowest: compound 4; then compound 2; then compound 3; then compound 1.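

In this assay, this position, two atoms from the ring nitrogen, accepts a saturated ring joined directly through carbon, with a 22-fold lower number from compound 3 to compound 4 (1.33 log units; beyond the scatter) and a 56-fold lower number from compound 1 to compound 4 (1.75 log units; beyond the scatter), so a ring-bearing acetylated group need not be linked through oxygen. The further modest step, a 2.2-fold lower number from compound 2 to compound 4 (0.34 log units; beyond the scatter), changes the five-membered ring to a six-membered one and removes the oxygen link together, so the two changes cannot be separated here. No measurement shown explains why the 1-acetylpiperidin-4-yl group gives this result.

Which part of that group matters remains open. A free amine on the piperidine or a methanesulfonyl group in place of the acetyl could test the acetyl's role, and a piperidine joined through oxygen could separate the link from the ring size.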